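The source may report more compounds than this note shows. Statements on the series, on what has been measured and on what is new or still open speak of the compounds shown alone.

Within the data shown here, the three compounds measured so far share a core and differ on the aryl ketone and the aniline. Compound 1 `COc1cc(C(=O)/C=C\Nc2ccc(-c3nc4cc(OC)c(OC)c(OC)c4s3)cc2)c(Br)c(OC)c1OC` gives 6600 nM in a functional assay on HeLa cells (Homo sapiens) for antiproliferative activity, read by sulforhodamine B assay, with a stated time of 48 h; on this read-out higher numbers stand for weaker inhibition and lower numbers for stronger inhibition. Compound 2 `COc1cc(OC)c2sc(-c3ccc(N/C=C\C(=O)c4ccc(OC)c(F)c4)c(C)c3)nc2c1` gives 14700 nM in this assay, and compound 3 `COc1ccc(C(=O)/C=C\Nc2ccc(-c3nc4cc(OC)c(OC)c(OC)c4s3)cc2)cc1[N+](=O)[O-]` gives 11400 nM in this assay. Compound 3 has the second highest of the three numbers; its nearest neighbour is compound 2, whose number is higher by an amount within the scatter, and the furthest is compound 1, whose number is lower by an amount also within the scatter. On these figures, therefore, the three compounds cannot be told apart.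

Compound 4 `COc1ccc(C(=O)/C=C\Nc2ccc(-c3nc4cc(OC)c(OC)c(OC)c4s3)cc2)cc1O` has not yet been measured in this assay. It differs from compound 3 in one place: hydroxy in place of nitro on an aromatic carbon. Among the measured compounds shown here, no pair of measured compounds shows a step of this kind, so the size and direction of its effect are not known from the data at hand. The step from compound 3 to compound 4 is expected to be a modest move toward stronger inhibition, a 2.1-fold lower number from compound 3 to compound 4 (0.32 log units; beyond the scatter), though a result within the scatter would not surprise. Compound 4 is accordingly expected to give about 5500 nM in this assay, with a range from 1800 nM to 16000 nM.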

Compound 4, half-maximal inhibitory concentration: 14100 nM
For compound 4 the middle estimate is 2.6-fold (0.41 log units) below the measured one, within the range that was stated.
By their numbers in this assay, from the lowest: compounds 1, 3, 4 and 2 (each within the scatter of the next, the first and the last beyond it).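

Among these compounds, on the aryl ketone of this series, the change from 4-methoxy-3-nitrophenyl to 3-hydroxy-4-methoxyphenyl gives the only step that can be read directly, and in this assay it comes to a 1.2-fold higher number from compound 3 to compound 4 (0.09 log units; within the scatter). Hydroxy and nitro on this aromatic carbon, ortho to a methoxy group, therefore cannot be told apart on this read-out, even though the exchange removes a group of three heavy atoms that has no hydrogen-bond donor and puts in a single oxygen that has one. No measured property of these compounds is at hand to account for this result.

The compounds shown leave open whether an amine or a carboxylic acid on this same aromatic carbon would also stay within the scatter of compound 3, or whether either would move the number clearly in one direction. They also leave open whether an ethoxy group in place of the methoxy group would change the picture, and whether the exchange of nitro for hydroxy would read the same way on a different aniline.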